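Opening the ring of compound 3: working notes

The compounds below may be only part of what the source reports. "The series", "measured", "known", "first", "only" and "open" are said of these compounds alone.

compound 1 `O=C(CCCCC1CCSS1)Nc1ccccn1`: 0.89%
compound 2 `O=C(CCCCC1CCSS1)Nc1ccc(Cl)cn1`: "not active" (no number reported)
compound 3 `O=C(CCCCC1CCSS1)Nc1ccc(Br)cn1`: "not active" (no number reported)

All three entries come from a functional assay on Bel-7402 cells (Homo sapiens) for inhibition, read by MTT assay, with a stated time of 24 h, tested at 0.1 ug/mL; on this read-out higher numbers stand for more inhibition of growth at the one concentration tested and lower numbers for less inhibition of growth. Only compound 1 has a single number. For the measured compounds named here, compound 3 has none: it is reported as "not active" (no number reported), and compound 2 carries the same kind of entry, so no numerical step can be drawn among the three.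

Compound 4 `O=C(CCCCC(S)CCS)Nc1ccc(Br)cn1` has not yet been measured. The structural change is a group of 5 heavy atoms (3 carbon, 2 sulfur; no ring) in place of a group of 5 heavy atoms (3 carbon, 2 sulfur; one five-membered non-aromatic ring with 2 hetero atoms), on a saturated chain carbon, four bonds along the chain from a carbonyl carbon. In words, a 1,3-disulfanylpropyl group, with no ring, takes the place of the five-membered non-aromatic ring, on a saturated chain carbon, four bonds along the chain from a carbonyl carbon.

Going by the values given here, no compound without that ring has been measured, so the data say nothing direct about this change. In this assay the expected outcome is no step beyond the scatter, with any movement more likely upward, since compound 3 has no number to fall from. Another entry without a number would also fit. Among the compounds with values here, the only numerical anchor is compound 1 at 0.89%.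

For compound 4 the estimated value is 5%, with an expected range from 0% to 20%.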

Compound 4, percent growth inhibition at one concentration: "not active" (no number reported)
Nothing numeric was reported for compound 4; no gap can be computed for the estimate.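

In this assay compound 3 and compound 4 both carry entries without a single number, so no step can be read between them. The compounds shown leave open whether replacing the ring with the 1,3-disulfanylpropyl group shifts growth inhibition at all. No measured evidence bears on this result.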